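Amide substituent change in a vitamin D receptor agonist series

A few compounds are considered here, and "the series" means these few. Any claim that something is new, unique, unknown or untested is made for them only; others in the source may bear on it.

compound 1 `CCOC(=O)CN(C)C(=O)c1ccc(C(CC)(CC)c2ccc(OCC(=O)C(C)(C)C)c(C)c2)n1CC`: > 50000 nM
compound 2 `CCn1c(C(=O)NCCCN(C)C)ccc1C(CC)(CC)c1ccc(OCC(=O)C(C)(C)C)c(C)c1`: 96 nM
compound 3 `CCn1c(C(=O)N(C)CCC#N)ccc1C(CC)(CC)c1ccc(OCC(=O)C(C)(C)C)c(C)c1`: to be measured

In an assay on HL-60 cells for agonist activity at vitamin D3 receptor (Homo sapiens), read by microscopy, with a stated time of 96 h (on this read-out higher numbers stand for an effect only at larger amounts of compound and lower numbers for an effect already at smaller amounts), compound 1 gives > 50000 nM, which is a limit of the assay and not a number, as shown by the limit of > 50000 nM in this assay, at which 1 of the 2 values shown sits. In this assay compound 2 gives 96 nM. Among the compounds with values here, the only measured step, an at least 520-fold lower number from compound 1 to compound 2 (2.71 log units; beyond the scatter), replaces the whole substituent on the carbonyl carbon and is large. Compound 3 differs from compound 1 by cyanomethyl in place of ethoxycarbonyl on a saturated chain carbon bound to an amide-type nitrogen; the methyl on the amide-type nitrogen stays, so this change is narrower than the measured one, and the measured step bears on it only loosely. Some movement toward lower numbers is expected for compound 3, but not the full size of the measured step, giving an expected at least 5.0-fold lower number from compound 1 to compound 3 (0.69 log units; beyond the scatter). Compound 3 is therefore estimated at 10000 nM, with a range from 500 nM to 50000 nM.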

Compound 3, half-maximal effective concentration: 9800 nM
The estimate for compound 3 lay 1.0-fold (0.01 log units) above the measured number; measured number inside the range.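

In this assay, cyanomethyl in place of ethoxycarbonyl on a saturated chain carbon bound to an amide-type nitrogen gives an at least 5.1-fold lower number from compound 1 to compound 3 (0.70 log units; beyond the scatter), so a substituent that keeps the methyl on the amide-type nitrogen can still give a measurable number. Compound 1 stands at a limit of the assay and not at a number: the limit of > 50000 nM in this assay, at which 1 of the 3 values shown sits. Against (3-(dimethylamino)propyl)amino on a carbonyl carbon, (2-cyanoethyl)(methyl)amino gives a 100-fold higher number from compound 2 to compound 3 (2.01 log units; beyond the scatter), so the nitrile-bearing substituent closes only part of the gap seen earlier.

That last step changes the whole substituent, so it cannot show whether the dimethylamino group, the nitrile or the amide hydrogen accounts for the difference. A (3-(dimethylamino)propyl)(methyl)amino substituent would separate the amide hydrogen from the amine, and a carboxylic acid in place of ethoxycarbonyl remains an open comparison.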